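This account rests on a few compounds, and the source may have more. Where it says the series, first, only, none or still open, it means among the compounds named here.

In a functional assay on HepG2 cells (Homo sapiens) for cytotoxicity, read by MTT assay, with a stated time of 24 h (on this read-out lower numbers stand for stronger inhibition and higher numbers for weaker inhibition), compound 1 `CN1C/C(=C\c2cccnc2)C(=O)/C(=C/c2ccc(F)cc2Br)C1` gives 13000 nM and compound 2 `COc1cc(/C=C2\CN(C)C/C(=C\c3ccncc3)C2=O)cc(OC)c1OC` gives 9800 nM as two values within the usual scatter of each other. Compound 3 `O=C1/C(=C/c2cccnc2)CN(S(=O)(=O)c2ccc(C(F)(F)F)cc2)C/C1=C\c1ccccc1F` at 2400 nM has the lowest number of the three and stands beyond the scatter from both. Compound 4 `CC(=O)Nc1ccc(S(=O)(=O)N2C/C(=C\c3cccnc3)C(=O)/C(=C/c3ccccc3F)C2)cc1` has not been measured. The change from compound 3 is acetamido in place of trifluoromethyl on an aromatic carbon and reads acetamido in place of trifluoromethyl on an aromatic carbon, para to a large group. For the measured compounds named here, no measured pair differs in one place, so nothing here sizes this change directly. The rest of compound 4 matches compound 3, which makes 2400 nM the starting point. With compound 3 already lowest, a move up towards compound 2 at 9800 nM seems more likely than a further drop. In this assay the estimated step is a 1.7-fold higher number from compound 3 to compound 4 (0.22 log units; within the scatter) and is expected to be small, towards weaker inhibition, and perhaps not beyond the scatter. For compound 4 the expected value is 4000 nM with an estimated range from 1500 nM to 11000 nM as the working figure.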

Compound 4, half-maximal inhibitory concentration: 4560 nM
The estimate for compound 4 lay 1.1-fold (0.06 log units) below the measured number; low and high end bracket the measured number.
By their numbers in this assay, from the lowest: compounds 3 and 4 (each within the scatter of the next); then compounds 2 and 1 (each within the scatter of the next).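

In this assay, for the compounds shown here, compounds 3 and 4 form the first pair that differs in one place, giving a 1.9-fold higher number from compound 3 to compound 4 (0.28 log units; within the scatter). At this aromatic carbon, para to a large group, acetamido brings a hydrogen-bond donor and a hydrogen-bond acceptor where trifluoromethyl brings neither, and the step stays within the scatter, so this position accepts either group with no readable difference in this read-out. Nothing available accounts for this result.

On these data alone, whether an amine, a carboxylic acid or a longer amide chain at the same carbon would also stay within the scatter of compound 3 remains open. Also open, as far as these compounds go, is whether the exchange reads the same with another group on the nitrogen-bearing core or other aryl groups on the rest of the molecule.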